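A few compounds are considered here, and "the series" means these few. Any claim that something is new, unique, unknown or untested is made for them only; others in the source may bear on it.

Measured compounds in an assay on CHO cells for displacement of a labelled ligand from adenosine receptor A1 (Homo sapiens), read by scintillation counting, with a stated time of 90 min, in the presence of a further agent that is not named here; on this read-out lower numbers stand for stronger inhibition and higher numbers for weaker inhibition:
Compound 1 `CCCn1c(=O)c2[nH]c(-c3ccc(S(=O)(=O)N4CCN(c5ccc(Cl)cc5)CC4)cc3)nc2n(CC)c1=O`: compound 1 gives > 1000 nM, a limit of the assay.
Compound 2 `CCCn1c(=O)[nH]c2nc(-c3ccc(S(=O)(=O)N4CCN(Cc5ccc(Br)cc5)CC4)cc3)[nH]c2c1=O`: compound 2 gives > 1000 nM, a limit of the assay.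
Compound 3 `CCCn1c(=O)c2[nH]c(-c3ccc(S(=O)(=O)N4CCN(c5ccc(Cl)cc5)CC4)cc3)nc2n(C)c1=O`: compound 3 gives > 1000 nM, a limit of the assay.

Compound 2 stands at the limit, and every value shown sits there (the limit of > 1000 nM in this assay, at which 3 of the 3 values shown sit). Among the measured compounds shown here, the single step between measured compounds, a step that the two limits leave unreadable from compound 1 to compound 3, is unreadable because both ends are limits. Compound 4 `CCCn1c(=O)[nH]c2nc(-c3ccc(S(=O)(=O)N4CCN(c5ccc(Br)cc5)CC4)cc3)[nH]c2c1=O` differs from compound 2 by 4-bromophenyl in place of 4-bromobenzyl on an amine nitrogen in a ring. For the measured compounds named here, no measured step covers this change; compounds 1 and 3, which also carry an aryl group on that ring nitrogen, sit at the limit. The writer therefore expects no readable step in this assay and estimates compound 4 at 3000 nM, in the range 1000 nM to 10000 nM, a step that the limit leaves unreadable from compound 2 to compound 4 that is expected to remain unreadable.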

Compound 4, inhibition constant: > 1000 nM
Compound 4 was reported as a limit (the forecaster's own chance of this, stated with the estimate: 80%); the middle value lies beyond the limit too.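

Among the compounds shown here, compound 2 and compound 4 both stand at a limit of the assay, so no step between them can be read: the limit of > 1000 nM in this assay, at which 4 of the 4 values shown sit.

The compounds shown leave open how far each lies beyond that limit, and whether 4-bromophenyl or 4-bromobenzyl on an amine nitrogen in a ring gives stronger inhibition.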